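The compounds below may be only part of what the source reports. "The series", "measured", "known", "first", "only" and "open" are said of these compounds alone.

Measured so far, in a functional assay on HCT-116 cells (Homo sapiens) for cytotoxicity, read by crystal violet staining, with a stated time of 7 days; a higher number here means a weaker inhibitor, a lower number a stronger inhibitor:

Compound 1 `COc1cc(OC)cc(C(=O)/C=C/C2=Cc3cc(Br)ccc3OC2)c1` gives 3400 nM.
Compound 2 `COc1cccc(C(=O)/C=C/C2=Cc3cc(Br)ccc3OC2)c1` gives 4560 nM.
Compound 3 `COc1ccc2c(c1)C=C(C(=O)/C=C/c1cc(OC)c(OC)cc1OC)CO2` gives 2500 nM.

Compound 1 and compound 2 share one core; the change between them is hydrogen in place of methoxy on an aromatic carbon, and it moved this assay by a 1.3-fold higher number from compound 1 to compound 2 (0.13 log units; within the scatter). Compound 3 carries the other core of the series; the difference between the two cores is not broken down here, and its value sits within the scatter of both compound 1 and compound 2.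

Compound 4 `COc1ccc2c(c1)C=C(C(=O)/C=C/c1ccc(OC)cc1OC)CO2` is not yet measured. It differs from compound 3 by hydrogen in place of methoxy on an aromatic carbon. This is the same kind of change as that from compound 1 to compound 2, though the surroundings differ: in compound 3 the place is ortho to a methoxy group and para to a methoxy group, whereas in compound 1 it is meta to a methoxy group; in both it is meta to a large group.

For compound 4 a step of a 1.3-fold higher number from compound 3 to compound 4 (0.11 log units; within the scatter) is expected, resting on the small shift a 1.3-fold higher number from compound 1 to compound 2 (0.13 log units; within the scatter) seen with the same change on the other core. Compound 4 is thus estimated at 3200 nM, with a likely range of 1800 nM to 6000 nM.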

Compound 4, half-maximal inhibitory concentration: 3970 nM
Beside the measured number, compound 4's estimate is 1.2-fold (0.09 log units) below it; low and high end bracket the measured number.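

In this assay, hydrogen in place of methoxy gives a 1.6-fold higher number from compound 3 to compound 4 (0.20 log units; within the scatter), and the comparison with the same change on the other core shows no difference beyond the scatter: the same change on two cores in this assay, a 1.3-fold higher number (0.13 log units; within the scatter) from compound 1 to compound 2 and a 1.6-fold higher number (0.20 log units; within the scatter) from compound 3 to compound 4, 1.2-fold (0.07 log units) apart, within the scatter of two such steps

On these two cores, the change therefore carries over without a detectable difference, and neither step can be told apart from repeat-measurement scatter. This does not show that the methoxy group matters on either core, nor that the agreement would hold on a third core or at another place on the ring; it rests on two pairs, and the surroundings of the changed place differ between them.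

Every step shown replaces methoxy with hydrogen, leaving open whether an amine, a carboxylic acid or a longer alkoxy chain at that place would move the number beyond the scatter. No pair shown differs in the core alone, so the contribution of the core itself also remains open.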